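A few compounds are considered here, and "the series" means these few. Any claim that something is new, unique, unknown or untested is made for them only; others in the source may bear on it.

Measured compounds in an assay on isolated protein (plasma) for inhibition of coagulation factor X (Oryctolagus cuniculus); on this read-out higher numbers stand for weaker inhibition and lower numbers for stronger inhibition:
compound 1 `O=C(NC[C@H]1CN(c2ccc(-n3cccc3CN3CCC3)cc2)C(=O)O1)c1ccc(Cl)s1` gives 1520 nM
compound 2 `O=C(NC[C@H]1CN(c2ccc(-n3cccc3CN3CCCC3)cc2F)C(=O)O1)c1ccc(Cl)s1` gives 3010 nM
compound 3 `CCN(CC)Cc1csc(-c2ccc(N3C[C@H](CNC(=O)c4ccc(Cl)s4)OC3=O)cc2)n1` gives 1030 nM

Compound 3 holds the lowest of the three numbers in this assay. Its nearest neighbour is compound 1, and the step of a 1.5-fold lower number from compound 1 to compound 3 (0.17 log units; within the scatter) stays within the scatter, so the two cannot be ordered. Within the data shown here, compound 2 sits further off, beyond the scatter from compound 3; no single-change step links compound 2 to either of the others, so its number is taken on its own.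

Compound 4 `CC1CCN(Cc2csc(-c3ccc(N4C[C@H](CNC(=O)c5ccc(Cl)s5)OC4=O)cc3)n2)CC1` is not yet measured. It differs from compound 3 by 4-methylpiperidin-1-yl in place of diethylamino on a saturated chain carbon bound to an aromatic carbon; read one bond further out, (diethylamino)methyl becomes (4-methylpiperidin-1-yl)methyl.

Among the measured compounds shown here, the only measured step that touches the amine attached to this saturated chain carbon is a 1.5-fold lower number from compound 1 to compound 3 (0.17 log units; within the scatter), which also swaps the aromatic group carrying it and still remains within the scatter. For the measured compounds named here, no step varies the amine alone. On that basis the change from compound 3 to compound 4 is expected to give no step beyond the scatter in this assay, the expected step being a 1.1-fold lower number from compound 3 to compound 4 (0.06 log units; within the scatter).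

For compound 4 the estimate in this assay is 900 nM, expected to lie between 400 nM and 2200 nM.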

Compound 4, half-maximal inhibitory concentration: 4020 nM
Estimate against measurement, compound 4: 4.5-fold (0.65 log units) below; measured number outside the range, above it.
By their numbers in this assay, from the lowest: compounds 3, 1, 2 and 4 (each within the scatter of the next, the first and the last beyond it).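

In this assay, among these compounds, the amine on this saturated chain carbon bound to an aromatic carbon proves sensitive to change: a 3.9-fold higher number from compound 3 to compound 4 (0.59 log units; beyond the scatter) is the first step that varies the amine alone, and unlike the earlier step that also swapped the aromatic group, it lies beyond the scatter. The change takes the amine from diethylamino, with 5 heavy atoms and no ring, to 4-methylpiperidin-1-yl, with 7 heavy atoms and one six-membered non-aromatic ring, while the hydrogen-bond donor and acceptor counts and the net charge stay the same, so the step arises without any change in those counts. Nothing available bears on why the number rises at this step.

On these data alone, it remains open whether the step follows the ring or the methyl group, which piperidin-1-yl without the methyl, morpholin-4-yl or dimethylamino on the same chain carbon would help to separate. As far as these compounds go, it is also open whether the same amine change would give a similar step on the 2-((azetidin-1-yl)methyl)-1H-pyrrol-1-yl scaffold of compound 1.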